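Methoxy for Fluoro in a Cytotoxic Series on L1210 Cells

The source may hold more compounds than are shown below. What is called first, only, known or untested is meant among the compounds shown, and "the series" means these compounds.

Measured compounds:
Compound 1, `Cc1ccc(/C=C2\CCC/C(=C\c3ccc([N+](=O)[O-])cc3)C2=O)cc1`: in a functional assay on L1210 cells (Mus musculus) for cytotoxicity, with a stated time of 48 h (on this read-out lower numbers stand for stronger inhibition and higher numbers for weaker inhibition), compound 1 gives 8160 nM.
Compound 2, `O=C1/C(=C/c2ccc(F)cc2)CCC/C1=C\c1cccc([N+](=O)[O-])c1`: in this assay compound 2 gives 16300 nM.
Compound 3, `O=C1/C(=C/c2ccc(Cl)cc2)CCC/C1=C\c1ccccc1[N+](=O)[O-]`: in this assay compound 3 gives 9380 nM.

Three compounds share one core and differ in the substituents on their two aromatic rings. Compound 2 returns the largest of the three numbers in this assay, yet its gap to compound 3 and its gap to compound 1 both fall within the usual scatter of repeated measurements, so the three results cannot be told apart with confidence. No pair among these three differs in a single place, so no single-change step is available to guide an expectation.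

The unmeasured compound 4, `COc1ccc(/C=C2\CCC/C(=C\c3cccc([N+](=O)[O-])c3)C2=O)cc1`, is reached from compound 2 by one change: methoxy in place of fluoro on an aromatic carbon. Taken one bond further out, this reads as 4-fluorophenyl to 4-methoxyphenyl, the group sitting para to a large group.

For the measured compounds named here, with no comparable step among the measured compounds, the expected step from compound 2 to compound 4 in this assay is estimated as a 1.3-fold lower number from compound 2 to compound 4 (0.10 log units; within the scatter), that is, no change beyond the scatter in either direction. Compound 4 is therefore expected to give about 13000 nM in this assay, within a range of 4500 nM to 40000 nM.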

Compound 4, half-maximal inhibitory concentration: 29500 nM
The estimate for compound 4 lay 2.3-fold (0.36 log units) below the measured number; the range from low to high includes it.
By their numbers in this assay, from the lowest: compounds 1, 3, 2 and 4 (each within the scatter of the next, the first and the last beyond it).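

For the compounds shown here, compound 2 and compound 4 provide the only single-change step in this set, and in this assay it reads a 1.8-fold higher number from compound 2 to compound 4 (0.26 log units; within the scatter). It shows that at this aromatic carbon, para to a large group, replacing fluoro with methoxy, which brings an oxygen and a hydrogen-bond acceptor, does not move the number beyond the scatter in this pair, so the 4-fluorophenyl and 4-methoxyphenyl forms cannot be told apart on this read-out. Nothing available bears on how this result should be explained.

The compounds shown leave open whether a different group at this position, such as an amine, a carboxylic acid or a longer alkoxy chain, would give a step beyond the scatter. Going by these compounds alone, they also leave open whether the exchange of fluoro for methoxy would read the same way with other substituents on the second aromatic ring, since this single pair is the only evidence for it.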